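Side-chain change from compound 3 to compound 4

A few compounds are considered here, and "the series" means these few. Any claim that something is new, unique, unknown or untested is made for them only; others in the source may bear on it.

Values in a physicochemical assay for solubility, measured as kinetic solubility, at pH 7.4 (on this read-out lower numbers stand for lower solubility and higher numbers for higher solubility), so far:
- compound 1 `COc1cc(N2CCC(C(=O)N3CCC(N(C)C)C3)CC2)ccc1Nc1nc(NC2CCCCC2)c2nc[nH]c2n1` gives 38000 nM
- compound 2 `COc1cc(N2CCC(CC(=O)N3CCOCC3)CC2)ccc1Nc1nc(NC2CCCCC2)c2nc[nH]c2n1` gives 19000 nM
- compound 3 `CCN(CC)CC1CCN(c2ccc(Nc3nc(NC4CCCCC4)c4nc[nH]c4n3)c(OC)c2)CC1` gives 19000 nM

Compound 3 is not separated from the other two: the steps read no change at the digits printed from compound 2 to compound 3 (within the scatter) and a 2.0-fold lower number from compound 1 to compound 3 (0.30 log units; within the scatter) and both stay within the scatter.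

Compound 4 `COc1cc(N2CCC(CC(=O)N3CCCC3)CC2)ccc1Nc1nc(NC2CCCCC2)c2nc[nH]c2n1` carries (pyrrolidin-1-yl)carbonyl in place of diethylamino on a saturated chain carbon bound to a saturated ring carbon. Among the compounds with values here, no measured compound has this exact group at this place. The nearest evidence is the swap at the same place already cited, from compound 2, together with a 2.0-fold lower number from compound 1 to compound 2 (0.30 log units; within the scatter) and neither moves the number beyond the scatter. The three measured side chains thus give no sign of a real step, though three compounds are a thin basis.

Expected is a 1.2-fold lower number from compound 3 to compound 4 (0.07 log units; within the scatter) in this assay and so no step beyond the scatter. For compound 4 the estimated value is 16000 nM with an expected range from 7000 nM to 36000 nM on this read-out.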

Compound 4, solubility: 19000 nM
The estimate for compound 4 lay 1.2-fold (0.07 log units) below the measured number; the range from low to high includes it.
By their numbers in this assay, from the lowest: compounds 2, 3, 4 and 1 (each within the scatter of the next).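

In this assay, (pyrrolidin-1-yl)carbonyl on a saturated chain carbon bound to a saturated ring carbon does not separate compound 4 from any earlier compound (no change at the digits printed from compound 3 to compound 4 (within the scatter); a 2.0-fold lower number from compound 1 to compound 4 (0.30 log units; within the scatter)). The step between pyrrolidin-1-yl and morpholin-4-yl on a carbonyl carbon isolates the ring on the carbonyl as the only difference, and it too stays inside the scatter (no change at the digits printed from compound 2 to compound 4 (within the scatter)). All four side chains shown therefore lie within the scatter of the next in this read-out, and nothing available speaks to the reason for this result.

Still open, from the compounds shown here alone, is whether a carboxylic acid or a piperazine at this place would give a step beyond the scatter. Also open, going by these compounds, is whether a longer chain between the saturated ring carbon and the carbonyl would do so.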